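A few compounds are considered here, and "the series" means these few. Any claim that something is new, unique, unknown or untested is made for them only; others in the source may bear on it.

Measured compounds:
compound 1 `COc1ncc(-c2ccc3nc(N)nn3c2)cc1NS(=O)(=O)c1ccc(F)cc1` — 2970 nM
compound 2 `COc1ncc(-c2ccc3nc(N)nn3c2)cc1NS(=O)(=O)c1ccc(Cl)cc1` — 2500 nM

In a functional assay on HCT-116 cells (Homo sapiens) for antiproliferative activity, read by MTT assay, with a stated time of 48 h (on this read-out higher numbers stand for weaker inhibition and lower numbers for stronger inhibition), compound 1 gives 2970 nM, the highest of the two numbers recorded. Its nearest neighbour is compound 2, which in this assay gives 2500 nM; the step of a 1.2-fold lower number from compound 1 to compound 2 (0.07 log units; within the scatter) lies within the scatter, so the two values cannot be told apart.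

Compound 3 `CCOC(=O)CNc1nc2ccc(-c3cnc(OC)c(NS(=O)(=O)c4ccc(F)cc4)c3)cn2n1` has not yet been measured in this assay. It differs from compound 1 by (ethoxycarbonyl)methyl in place of hydrogen on a nitrogen on an aromatic ring; the same difference, cut one bond further out, reads amino to ((ethoxycarbonyl)methyl)amino. Among the compounds with values here, the only measured step, from compound 1 to compound 2, concerns chloro in place of fluoro on an aromatic carbon, a different place in the molecule, and it was within the scatter. Within the data shown here, no measured step therefore bears on the change at the ring nitrogen, and the data give no ground for expecting a shift in either direction beyond the scatter. The estimate for compound 3 in this assay is accordingly 3000 nM, with a range from 800 nM to 12000 nM, which corresponds to an expected step of a 1.0-fold higher number from compound 1 to compound 3 (0.00 log units; within the scatter).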

Compound 3, half-maximal inhibitory concentration: 4370 nM
The estimate for compound 3 lay 1.5-fold (0.16 log units) below the measured number; the range from low to high includes it.
By their numbers in this assay, from the lowest: compounds 2, 1 and 3 (each within the scatter of the next).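

In this assay, within the data shown here, the change from amino to ((ethoxycarbonyl)methyl)amino gives a 1.5-fold higher number from compound 1 to compound 3 (0.17 log units; within the scatter), and this is the first reading that bears on this nitrogen on an aromatic ring. The earlier pair spoke only of a halogen on an aromatic carbon, whereas this step shows that the nitrogen can carry the (ethoxycarbonyl)methyl chain without a number that can be told apart from that of compound 1. This single step describes one substituent in one cell assay, and nothing measured alongside it accounts for the outcome.

What the compounds shown leave open is whether the chain or its ethoxycarbonyl end has any bearing on the number, which a carboxylic acid in place of that end, a plain methyl or a longer chain on the same nitrogen could address. They also leave open whether (ethoxycarbonyl)methyl on this nitrogen would give a comparable reading when paired with the chloro group of compound 2 rather than the fluoro group of compound 1.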